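From nitro to trifluoromethyl on the shared core

The source may hold more compounds than are shown below. What is called first, only, known or untested is meant among the compounds shown, and "the series" means these compounds.

Among the measured compounds shown here, in an ADME assay on HeLa cells (Homo sapiens) for cytotoxicity, read by crystal violet staining, with a stated time of 72 h (a lower number here means that less compound is tolerated, a higher number that more compound is tolerated), compound 1 `CN(C)C(=O)c1cc(CCCOc2ccc(-c3noc(C(F)(F)F)n3)cc2)on1` gives 28000 nM, and compound 2 `CN(C)C(=O)c1cc(CCCOc2ccc(-c3noc(C(F)(F)F)n3)cc2[N+](=O)[O-])on1` gives 22500 nM, so compound 2 stands within the scatter of the only other measured value. Compound 3 `CN(C)C(=O)c1cc(CCCOc2ccc(-c3noc(C(F)(F)F)n3)cc2C(F)(F)F)on1` differs from compound 2 as follows: trifluoromethyl in place of nitro on an aromatic carbon. For the measured compounds named here, only one measured step bears on this position, a 1.2-fold lower number from compound 1 to compound 2 (0.09 log units; within the scatter), so no step beyond the scatter is expected in this assay. Compound 3 is estimated at 25000 nM, with a range of 12000 nM to 50000 nM. This estimate means an expected 1.1-fold higher number from compound 2 to compound 3 (0.05 log units; within the scatter).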

Compound 3, half-maximal cytotoxic concentration: 19200 nM
Compound 3: middle estimate off by 1.3-fold (0.11 log units), on the high side, and the stated range covers the measured number.
By their numbers in this assay, from the lowest: compounds 3, 2 and 1 (each within the scatter of the next).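

In this assay trifluoromethyl on the aromatic carbon ortho to a large group brings a 1.2-fold lower number from compound 2 to compound 3 (0.07 log units; within the scatter) when it replaces nitro and a 1.5-fold lower number from compound 1 to compound 3 (0.16 log units; within the scatter) when it replaces hydrogen. Across compound 1, compound 2 and compound 3, this position has therefore held hydrogen, nitro and trifluoromethyl with no step beyond the scatter. No supporting evidence bears on this result. On these data alone, whether an amine, a carboxylic acid or a longer alkyl chain at this position would stay within the scatter remains open. So does whether any group placed here can move the number beyond it.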